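Adding Chloro to the Most Active Urea

A few compounds are considered here, and "the series" means these few. Any claim that something is new, unique, unknown or untested is made for them only; others in the source may bear on it.

Three compounds sharing one core were tested in a functional assay on Malme-3M cells (Homo sapiens) for inhibition, read by sulforhodamine B assay, with a stated time of 48 h, tested at 10 uM; a higher number here means a weaker effect of the compound at the concentration tested, a lower number a stronger effect. Compound 1 `COc1cc2cc(Oc3ccc(NC(=O)Nc4ccccc4)cc3)c(C)nc2cc1OC` gives 86.4%. Compound 2 `COc1cc2cc(Oc3ccc(NC(=O)Nc4ccc(C)cc4)cc3)c(C)nc2cc1OC` gives 94.6% in this assay, and the step of a number 8.2 percentage points higher from compound 1 to compound 2 (within the scatter) lies within the scatter. Compound 3 `COc1cc2cc(Oc3ccc(NC(=O)Nc4cccc(C(F)(F)F)c4)cc3)c(C)nc2cc1OC` gives 7.22% in this assay, the lowest of the three numbers and thus the strongest effect; the steps of a number 79.2 percentage points lower from compound 1 to compound 3 (beyond the scatter) and a number 87.4 percentage points lower from compound 2 to compound 3 (beyond the scatter) are both large and beyond the scatter.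

Compound 4 `COc1cc2cc(Oc3ccc(NC(=O)Nc4ccc(Cl)c(C(F)(F)F)c4)cc3)c(C)nc2cc1OC` has not yet been measured. It differs from compound 3 by chloro in place of hydrogen on an aromatic carbon. For the measured compounds named here, no measured step shows what adding chloro does here; the measured steps only show that the trifluoromethyl group present in compound 3 goes together with a strong effect, and compound 4 keeps that group. Compound 3 already sits near the bottom of the scale in this assay with 7.22%, leaving little room for a lower number. Compound 4 is therefore expected to give about 8%, between 0% and 30%. The expected step of a number 0.8 percentage points higher from compound 3 to compound 4 (within the scatter) is estimated to stay within the scatter.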

Compound 4, a percentage reported as activity, at one concentration (the size of the read-out at that concentration, not a potency): -23%
Compound 4: the middle estimate sits 31 percentage points above what was measured, outside the stated range (below it).
By their numbers in this assay, from the lowest: compound 4; then compound 3; then compounds 1 and 2 (each within the scatter of the next).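

The aromatic carbon para to a large group and ortho to a trifluoromethyl group accepts chloro with a gain rather than a loss: a number 30.2 percentage points lower from compound 3 to compound 4 (beyond the scatter), so in this assay the number can still fall once trifluoromethyl is present, even to a value below zero. Set against the plain phenyl and the 4-methylphenyl, the full 4-chloro-3-(trifluoromethyl)phenyl group gives the two largest steps in the set, a number 109.4 percentage points lower from compound 1 to compound 4 (beyond the scatter) and a number 117.6 percentage points lower from compound 2 to compound 4 (beyond the scatter), making compound 4 the strongest of the four. Nothing shown here explains why chloro has this effect.

On these data alone, whether chloro would lower the number on a phenyl ring without trifluoromethyl remains open, so the share of each group in the effect of compound 4 cannot be separated. Whether fluoro, bromo or methoxy on this same carbon would act like chloro is also unknown.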